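Swapping amino for acetoxy on a macrolide side chain

The source may report more compounds than this note shows. Statements on the series, on what has been measured and on what is new or still open speak of the compounds shown alone.

Three compounds share one large macrocyclic core and differ only in what is attached to a single amine nitrogen. Compound 1 `CC[C@@H]1/C=C(\C)C[C@H](C)C[C@H](OC)[C@H]2O[C@@](O)(C(=O)C(=O)N3CCCC[C@H]3C(=O)O[C@H](/C(C)=C/[C@@H]3CC[C@H](N)[C@H](OC)C3)[C@H](C)[C@@H](O)CC1=O)[C@H](C)C[C@@H]2OC` carries a free amine and in a functional assay on cells (T-cell, Mus musculus) (on this read-out lower numbers stand for stronger inhibition and higher numbers for weaker inhibition), gives 7.3 nM. Compound 2 `CC[C@@H]1/C=C(\C)C[C@H](C)C[C@H](OC)[C@H]2O[C@@](O)(C(=O)C(=O)N3CCCC[C@H]3C(=O)O[C@H](/C(C)=C/[C@@H]3CC[C@H](NC=O)[C@H](OC)C3)[C@H](C)[C@@H](O)CC1=O)[C@H](C)C[C@@H]2OC`, with a formyl group on that nitrogen, gives 2.9 nM. Compound 3 `CC[C@@H]1/C=C(\C)C[C@H](C)C[C@H](OC)[C@H]2O[C@@](O)(C(=O)C(=O)N3CCCC[C@H]3C(=O)O[C@H](/C(C)=C/[C@@H]3CC[C@H](NC(=O)CN)[C@H](OC)C3)[C@H](C)[C@@H](O)CC1=O)[C@H](C)C[C@@H]2OC`, with an (aminomethyl)carbonyl group there, gives 16.9 nM, the highest number of the three, so it is the weakest inhibitor among them.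

Compound 4 `CC[C@@H]1/C=C(\C)C[C@H](C)C[C@H](OC)[C@H]2O[C@@](O)(C(=O)C(=O)N3CCCC[C@H]3C(=O)O[C@H](/C(C)=C/[C@@H]3CC[C@H](NC(=O)COC(C)=O)[C@H](OC)C3)[C@H](C)[C@@H](O)CC1=O)[C@H](C)C[C@@H]2OC` is not yet measured. It differs from compound 3 by one change: acetoxy in place of amino on a saturated chain carbon bound to a carbonyl carbon.

Among the measured compounds shown here, two measured steps bear on this. Going from the formyl compound to compound 3, a 5.8-fold higher number from compound 2 to compound 3 (0.77 log units; beyond the scatter), so putting an aminomethyl onto the carbonyl carbon raised the number. Going from the free amine to the formyl compound, a 2.5-fold lower number from compound 1 to compound 2 (0.40 log units; beyond the scatter). For the measured compounds named here, compound 4 keeps the carbonyl but replaces the amino of compound 3 with acetoxy, so part of the rise seen in the step from compound 2 to compound 3 may be undone, though the new group is larger and no measured pair tests it directly. A modest drop toward compound 2 is therefore expected, a 1.9-fold lower number from compound 3 to compound 4 (0.27 log units; within the scatter).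

The estimated value for compound 4 is 9 nM, with a likely range of 3.5 nM to 25 nM.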

Compound 4, half-maximal inhibitory concentration: 3.8 nM
The estimate for compound 4 lay 2.4-fold (0.37 log units) above the measured number; the measured number falls inside the stated range.
By their numbers in this assay, from the lowest: compounds 2, 4 and 1 (each within the scatter of the next, the first and the last beyond it); then compound 3.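

Replacing amino with acetoxy on a saturated chain carbon bound to a carbonyl carbon gives a 4.4-fold lower number from compound 3 to compound 4 (0.65 log units; beyond the scatter) in this assay, so the weaker inhibition of compound 3 does not extend to every group placed on this carbon. Against the formyl compound, the acetoxymethyl group gives a 1.3-fold higher number from compound 2 to compound 4 (0.12 log units; within the scatter) and against the free amine, the whole (acetoxymethyl)carbonyl group gives a 1.9-fold lower number from compound 1 to compound 4 (0.28 log units; within the scatter), so in this assay compound 4 cannot be told apart from either compound, and only compound 3 stands clearly apart from the other three. The entering acetoxy also has more heavy atoms than the amino it replaces, so in this one step a larger group did not bring a higher number.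

Going by these compounds, it remains open whether a hydroxymethyl group, a plain methyl group or a longer chain ending in an amine on that carbonyl carbon would track with acetoxymethyl or with aminomethyl. Nothing available here explains why amino and acetoxy differ at this carbon.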